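Nitro for bromo on a shared oxadiazole-free core? No: shared core

A few compounds are considered here, and "the series" means these few. Any claim that something is new, unique, unknown or untested is made for them only; others in the source may bear on it.

Measured so far:
Compound 1, `Brc1ccc(-c2nnc(Cn3nnc4ccccc43)o2)cc1`: 305000 nM
Compound 2, `Fc1cccc(-c2nnc(Cn3nnc4ccccc43)o2)c1`: 332000 nM

In a functional assay on HeLa cells (Homo sapiens) for antiproliferative activity, read by MTT assay, with a stated time of 24 h (on this read-out lower numbers stand for stronger inhibition and higher numbers for weaker inhibition), compound 1 gives 305000 nM, the lowest of the two numbers, with compound 2 at 332000 nM, and the step of a 1.1-fold higher number from compound 1 to compound 2 (0.04 log units; within the scatter) lies within the scatter. Compound 3, `O=[N+]([O-])c1ccc(-c2nnc(Cn3nnc4ccccc43)o2)cc1`, has not been measured; it differs from compound 1 by nitro in place of bromo on an aromatic carbon. Within the data shown here, the only step on record, a 1.1-fold higher number from compound 1 to compound 2 (0.04 log units; within the scatter), swaps one halogen-bearing ring for another and gives no guide to a nitro group. With nothing pointing either way, compound 3 is expected to show a 1.0-fold lower number from compound 1 to compound 3 (0.01 log units; within the scatter), meaning no step beyond the scatter. The estimate for compound 3 is 300000 nM, within 100000 nM to 900000 nM.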

Compound 3, half-maximal inhibitory concentration: 299000 nM
Compound 3: middle estimate off by 1.0-fold (0.00 log units), on the high side; the range from low to high includes it.
By their numbers in this assay, from the lowest: compounds 3, 1 and 2 (each within the scatter of the next).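

In this assay the change from bromo to nitro, on an aromatic carbon para to a large group, gives a 1.0-fold lower number from compound 1 to compound 3 (0.01 log units; within the scatter) and so no step beyond the scatter. The earlier step compared two halogen-bearing rings, whereas here a single bromine gives way to a larger group carrying hydrogen-bond acceptors, and the number holds. Nothing measured here explains this result. From the compounds shown here alone, whether an amine or a carboxylic acid at this position would move the number beyond the scatter remains open.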